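The compounds below may be only part of what the source reports. "The series", "measured", "known", "first", "only" and "open" are said of these compounds alone.

In a functional assay on MT4 cells (Homo sapiens) for cytotoxicity, read by MTT assay (on this read-out higher numbers stand for lower toxicity in this test and lower numbers for higher toxicity in this test), none of the three measured compounds gave a number. Compound 1 `COc1ccc(CCSc2nc(Cc3c(Cl)cccc3Cl)c(C)c(=O)[nH]2)cc1` gives only a limit, > 57000 nM. Compound 3 `COc1ccc(CSc2nc(O)c(C)c(Cc3c(F)cccc3F)n2)cc1` also gives only a limit, > 64000 nM. On these data alone, compound 2 `Cc1c(O)nc(SCc2ccc(Cl)cc2)nc1Cc1c(Cl)cccc1Cl` stands at a limit too, > 59000 nM, so its true position is unknown. Compound 4 `Cc1c(O)nc(SCc2cccc(F)c2)nc1Cc1c(Cl)cccc1Cl` differs from compound 2 in one place: 3-fluorophenyl in place of 4-chlorophenyl on a saturated chain carbon bound to a sulfur. This puts 3-fluorophenyl in place of 4-chlorophenyl on a saturated chain carbon bound to a sulfur. For the measured compounds named here, no measured step shows what such a change does in this assay. The estimated step that the limit leaves unreadable from compound 2 to compound 4 is expected to stay within the scatter, with no direction favoured. The expected value for compound 4 is 61000 nM, with an estimated range of 30000 nM to 90000 nM.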

Compound 4, half-maximal cytotoxic concentration: > 61000 nM
Compound 4 gave a limit, no number (the forecaster's own chance of this, stated with the estimate: 75%); the middle value lies on the limit itself.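

Compound 2 and compound 4 both gave only limits, so the step between them cannot be read. The compounds shown leave open whether 3-fluorophenyl in place of 4-chlorophenyl changes the toxicity at all, and where any true value lies.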